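Trading Amino for Chloro on One Aromatic Carbon

The compounds below may be only part of what the source reports. "The series", "measured", "known", "first", "only" and "open" are said of these compounds alone.

In an ADME assay on L1210/0 cells (Mus musculus) for cytotoxicity, with a stated time of 48 h (on this read-out lower numbers stand for stronger inhibition and higher numbers for weaker inhibition), compound 1 `CC(=O)OC(C)Cn1cnc2c(Cl)nc(I)nc21` gives 13000 nM. Compound 2 `CC(O)Cn1cnc2c(N)nc(I)nc21` reads > 200000 nM, which is a limit of the assay and not a number. Compound 3 `CC(=O)OC(C)Cn1cnc2c(N)nc(I)nc21` reads > 200000 nM, which is also a limit. Compound 2 therefore stands at the limit of > 200000 nM in this assay, at which 2 of the 3 values shown sit, and the question is what happens when one group on it is exchanged.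

Compound 4 `CC(O)Cn1cnc2c(Cl)nc(I)nc21` is still unmeasured. It differs from compound 2 as follows: chloro in place of amino on an aromatic carbon. Put simply, chloro takes the place of amino on an aromatic carbon, and the rest of the molecule stays the same.

For the measured compounds named here, two measured steps bear on this. Going by the values given here, the first is the same exchange in the opposite direction, with amino in place of chloro: an at least 15-fold higher number from compound 1 to compound 3 (1.18 log units; beyond the scatter), a large step beyond the scatter. The second adds acetyl in place of hydrogen on an oxygen, a step that the two limits leave unreadable from compound 2 to compound 3, so what that group contributes cannot be read.

Running the exchange backwards, and relying on an at least 15-fold higher number from compound 1 to compound 3 (1.18 log units; beyond the scatter), a large move towards a lower number is expected in this assay. The expected step is an at least 10-fold lower number from compound 2 to compound 4 (1.00 log units; beyond the scatter). Compound 4 is estimated at 20000 nM, with an expected range of 6000 nM to 80000 nM.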

Compound 4, half-maximal inhibitory concentration: > 200000 nM
Compound 4 was reported as a limit (the forecaster's own chance of this, stated with the estimate: 10%); at least 10-fold (1.00 log units) between middle value and limit.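

This result shows that chloro on this aromatic carbon does not bring a readable value on its own. With the chloro kept in place, putting hydrogen in place of acetyl on the oxygen gives an at least 15-fold higher number from compound 1 to compound 4 (1.18 log units; beyond the scatter) in this assay, so the acetyl also matters, which the amino compounds could not show. The effect of exchanging amino and chloro has therefore been read only with the acetyl present, since the steps from compound 2 to compound 3 and from compound 2 to compound 4 each join two limits and cannot be read. Compound 1 is now the only one of the set with a number, and the others all sit at the same limit: the limit of > 200000 nM in this assay, at which 3 of the 4 values shown sit.

The compounds shown leave open whether the acetyl itself is needed on that oxygen, or whether a benzoyl group or a methyl ether would serve as well. They also leave open whether bromo or a methylthio group on the aromatic carbon that carries the chloro would give a readable value, with or without the acetyl.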